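Cytotoxicity notes on the sulfonylindole carboxamide series

The source may hold more compounds than are shown below. What is called first, only, known or untested is meant among the compounds shown, and "the series" means these compounds.

Measured compounds:
- compound 1 `Cc1cc(C)cc(S(=O)(=O)c2c(C(=O)NCC(=O)NC(C)c3ccccc3)[nH]c3ccc(Cl)cc23)c1`: 29400 nM
- compound 2 `Cc1cc(C)cc(S(=O)(=O)c2c(C(=O)NCc3cccc(F)c3F)[nH]c3ccc(Cl)cc23)c1`: > 51100 nM
- compound 3 `Cc1cc(C)cc(S(=O)(=O)c2c(C(=O)NCc3ccc4nc(N)[nH]c4c3)[nH]c3ccc(Cl)cc23)c1`: 5890 nM

In an ADME assay on MT4 cells (Homo sapiens) for cytotoxicity, read by MTT assay (on this read-out higher numbers stand for lower toxicity in this test and lower numbers for higher toxicity in this test), compound 1 gives 29400 nM. Compound 2 reaches only a limit of the assay, (the limit of > 51100 nM in this assay, at which 1 of the 3 values shown sits). Compound 3 sits at 5890 nM, and compound 1 stands highest of the two numbers shown, with compound 3 nearest: a 5.0-fold lower number from compound 1 to compound 3 (0.70 log units; beyond the scatter). The step of an at least 1.7-fold higher number from compound 1 to compound 2 (0.24 log units; that floor lies within the scatter) stays within the scatter, while an at least 8.6-fold lower number from compound 2 to compound 3 (0.93 log units; beyond the scatter) is beyond it.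

Compound 4 `Cc1cc(C)cc(S(=O)(=O)c2c(C(=O)NCC(=O)NCCn3c(C)cnc3[N+](=O)[O-])[nH]c3ccc(Cl)cc23)c1` differs from compound 1 on the amide-type nitrogen: a group of 11 heavy atoms (6 carbon, 3 nitrogen, 2 oxygen; one five-membered aromatic ring with 2 hetero atoms) in place of a group of 8 heavy atoms (8 carbon; one six-membered aromatic ring of carbon only), on an amide-type nitrogen. Both measured steps from compound 1 alter the chain at a different place, so neither bears directly on this change. The two steps span from no change beyond the scatter to a modest lowering; the new group is unlike the 2-amino-1H-benzimidazol-6-yl of compound 3, so the expectation is that in this assay compound 4 stays near compound 1, estimated at 24000 nM (range 8000 nM to 60000 nM), meaning an expected step of a 1.2-fold lower number from compound 1 to compound 4 (0.09 log units; within the scatter) that need not exceed the scatter.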

Compound 4, half-maximal cytotoxic concentration: 24500 nM
Compound 4: the middle estimate sits 1.0-fold (0.01 log units) below what was measured; low and high end bracket the measured number.
By their numbers in this assay, from the lowest: compound 3; then compounds 4 and 1 (each within the scatter of the next). At a limit, above all of these: compound 2.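

In this assay, putting the group with the five-membered aromatic ring with 2 hetero atoms in place of 1-phenylethyl, on an amide-type nitrogen whose other neighbours are: carbonyl carbon, gives a 1.2-fold lower number from compound 1 to compound 4 (0.08 log units; within the scatter). This is the first change shown at this nitrogen, as the earlier steps all replaced a group on the saturated chain carbon. Here, the loss of the six-membered aromatic ring of carbon only and the gain in counted hydrogen-bond acceptors leave the number within the scatter, and nothing at hand accounts for this outcome.

Still open, from the compounds shown here alone, is whether a simple amine or a carboxylic acid on this nitrogen would also stay within the scatter of compound 1 in this assay. Also open, going by these compounds, is whether 2-amino-1H-benzimidazol-6-yl placed on this nitrogen would lower the number as it does on the saturated chain carbon.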